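A few compounds are considered here, and "the series" means these few. Any claim that something is new, unique, unknown or untested is made for them only; others in the source may bear on it.

Measured compounds:
compound 1 `Oc1cccc(-c2cc(-c3cccc(C(F)(F)F)c3)cc(-c3ccccc3O)n2)c1`, 13000 nM
compound 2 `Oc1cccc(-c2cc(-c3ccc(C(F)(F)F)cc3)cc(-c3ccccc3O)n2)c1`, > 50000 nM
compound 3 `Oc1ccc(-c2cc(-c3cccc(C(F)(F)F)c3)cc(-c3ccccc3O)n2)cc1`, > 50000 nM

In a functional assay on DU-145 cells (Homo sapiens) for inhibition (a higher number here means a weaker inhibitor, a lower number a stronger inhibitor), compound 1 gives 13000 nM. Compound 2 reaches only a limit of this assay, > 50000 nM. Compound 3 likewise stands at a limit, > 50000 nM. The change 4-(trifluoromethyl)phenyl in place of 3-(trifluoromethyl)phenyl on an aromatic carbon gave an at least 3.8-fold higher number from compound 1 to compound 2 (0.58 log units; beyond the scatter). The cores of compound 1 and compound 3 differ by 4-hydroxyphenyl in place of 3-hydroxyphenyl on an aromatic carbon, which gave an at least 3.8-fold higher number from compound 1 to compound 3 (0.58 log units; beyond the scatter). Both steps rest on (the limit of > 50000 nM in this assay, at which 2 of the 3 values shown sit).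

Compound 4 `Oc1ccc(-c2cc(-c3ccc(C(F)(F)F)cc3)cc(-c3ccccc3O)n2)cc1` has not yet been measured in this assay. It arises from compound 3 by 4-(trifluoromethyl)phenyl in place of 3-(trifluoromethyl)phenyl on an aromatic carbon, the same kind of change as from compound 1 to compound 2, though here the place is meta to a 4-hydroxyphenyl group rather than meta to a 3-hydroxyphenyl group. Given that compound 1 to compound 2 gave an at least 3.8-fold higher number from compound 1 to compound 2 (0.58 log units; beyond the scatter), compound 4 is expected to show a step that the limit leaves unreadable from compound 3 to compound 4. Compound 4 is estimated at 150000 nM, between 50000 nM and 600000 nM, most likely reported again only as a limit.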

Compound 4, half-maximal inhibitory concentration: > 50000 nM
Compound 4: only a limit was reported; the forecaster's own chance of this, stated with the estimate: 90%; the middle value lies beyond the limit too.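

In this assay compound 4 gives only a limit, > 50000 nM, so its steps from compound 2 and compound 3 cannot be read: the limit of > 50000 nM in this assay, at which 3 of the 4 values shown sit. Going by these compounds, whether compound 2, compound 3 and compound 4 truly differ from one another stays open.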